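The source may report more compounds than this note shows. Statements on the series, on what has been measured and on what is new or still open speak of the compounds shown alone.

The series rests on a shared core carrying an aminomethyl-style chain at the indole-type nitrogen. Compound 1 `O=C1c2c[n+]([O-])c3ccccc3c2C(=O)c2c1c1ccccc1n2Cc1cn([C@H]2O[C@H](CO)[C@@H](O)[C@H]2O)nn1` bears a sugar-linked triazole on that position, and in a functional assay on A-375 cells (Homo sapiens) for cytotoxicity, read by MTT assay, with a stated time of 72 h (a higher number here means a weaker inhibitor, a lower number a stronger inhibitor), compound 1 gives 340 nM. Compound 2 `O=C1c2c[n+]([O-])c3ccccc3c2C(=O)c2c1c1ccccc1n2CCCCn1ccnc1` instead carries a four-carbon chain ending in an imidazole, and in this assay compound 2 gives 350 nM. Where compound 2 stands is therefore plain: its number and that of compound 1 differ only within the usual scatter, so neither can be called the stronger or the weaker of the pair, and no ordered step exists between them.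

Compound 3 `CCCN1CCN(CCCCn2c3c(c4ccccc42)C(=O)c2c[n+]([O-])c4ccccc4c2C3=O)CC1` is the next, not yet measured member. Relative to compound 2 the change is 4-propylpiperazin-1-yl in place of 1H-imidazol-1-yl on a saturated chain carbon, four bonds along the chain from an aromatic nitrogen. Among the compounds with values here, no pair of measured compounds shows what this change does, so the expectation rests only on the closeness of compound 1 and compound 2 at the same end of the chain. A step from compound 2 to compound 3 of a 1.2-fold lower number from compound 2 to compound 3 (0.07 log units; within the scatter) is expected in this assay, that is, none beyond the scatter. Compound 3 is therefore estimated at 300 nM in this assay, with a range of 120 nM to 800 nM.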

Compound 3, half-maximal inhibitory concentration: 870 nM
Estimate against measurement, compound 3: 2.9-fold (0.46 log units) below; measured number above the stated range.
By their numbers in this assay, from the lowest: compounds 1 and 2 (each within the scatter of the next); then compound 3.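

Within the data shown here, this is the first ordered step: in this assay, 4-propylpiperazin-1-yl in place of 1H-imidazol-1-yl on a saturated chain carbon, four bonds along the chain from an aromatic nitrogen, gives a 2.5-fold higher number from compound 2 to compound 3 (0.40 log units; beyond the scatter). The step is modest but lies beyond the scatter, so the group at the end of this chain does register in the number, which compound 1 and compound 2 could not show, their values lying within the scatter of each other. Nothing among the data offers an explanation for this step.

A single step cannot separate the contribution of the piperazine ring from that of the propyl group it carries, and an unsubstituted piperazin-1-yl, a 4-methylpiperazin-1-yl or a morpholin-4-yl at the same place would bear on that question. On these data alone, it also remains open whether the step would keep its direction and size with 4-propylpiperazin-1-yl and 1H-imidazol-1-yl on a shorter or a longer chain, such as a two-carbon or a six-carbon one.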